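The source may hold more compounds than are shown below. What is called first, only, known or untested is meant among the compounds shown, and "the series" means these compounds.

Within the data shown here, compound 1 `CCCCNc1nc(N)nc(C)c1CCCc1ccccc1` is one of three compounds measured in an assay on HEK293 cells for agonist activity at Toll-like receptor 8 (Homo sapiens), read by spectrophotometry; on this read-out lower numbers stand for an effect already at smaller amounts and higher numbers for an effect only at larger amounts of compound; in that assay compound 1 gives 749 nM. Among the three numbers this is the second highest. Compound 2 `CCCCCc1c(C)nc(N)nc1NCCCC` gives 1220 nM, and the step of a 1.6-fold higher number from compound 1 to compound 2 (0.21 log units; within the scatter). Compound 3 `CCCCNc1nc(N)nc(C)c1CCCN(C)C` gives 126 nM, the lowest of the three, reached through the step of a 5.9-fold lower number from compound 1 to compound 3 (0.77 log units; beyond the scatter).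

The unmeasured compound 4 `CCCCNc1nc(N)nc(C)c1CCCN1CCN(C)CC1` differs from compound 1 in one place: 4-methylpiperazin-1-yl in place of phenyl on a saturated chain carbon, three bonds along the chain from an aromatic carbon. Among the measured compounds shown here, two measured steps bear on this change, since both put a group containing nitrogen in that same place: a 5.9-fold lower number from compound 1 to compound 3 (0.77 log units; beyond the scatter) and a 9.7-fold lower number from compound 2 to compound 3 (0.99 log units; beyond the scatter). Both gave a lower number, and the entering 4-methylpiperazin-1-yl also brings nitrogen into that place. A step in the same direction, of roughly similar size, is therefore expected in this assay, though whether a six-membered non-aromatic ring behaves like the small dimethylamino is not shown by any measured pair, so the range is kept wide. Compound 4 is expected to give 200 nM, with a likely range from 70 nM to 600 nM. That amounts to an expected step of a 3.7-fold lower number from compound 1 to compound 4 (0.57 log units; beyond the scatter).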

Compound 4, half-maximal effective concentration: 179 nM
Beside the measured number, compound 4's estimate is 1.1-fold (0.05 log units) above it; the measured number falls inside the stated range.
By their numbers in this assay, from the lowest: compounds 3 and 4 (each within the scatter of the next); then compounds 1 and 2 (each within the scatter of the next).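

In this assay, 4-methylpiperazin-1-yl gives a 4.2-fold lower number from compound 1 to compound 4 (0.62 log units; beyond the scatter), and in place of ethyl it gives a 6.8-fold lower number from compound 2 to compound 4 (0.83 log units; beyond the scatter), so the drop seen earlier with dimethylamino at this place also appears with a second nitrogen-containing group, and none of the four compounds goes against this. The change from dimethylamino to 4-methylpiperazin-1-yl is a 1.4-fold higher number from compound 3 to compound 4 (0.15 log units; within the scatter), so compounds 3 and 4 cannot be told apart. Among these compounds, this answers what the earlier compounds could not show: at this place on the saturated chain, a six-membered non-aromatic ring with 2 hetero atoms keeps a number that cannot be separated from that of the small open dimethylamino group.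

Still open, going by these compounds, is which part of the ring matters: piperidin-1-yl would drop the second ring nitrogen, morpholin-4-yl would put an oxygen there, and a simple primary amine or a longer chain leading to the dimethylamino group would test other features of this place. Nothing measured here explains why the nitrogen-containing groups give the lower numbers.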